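Adding a Trifluoromethyl Group to the Fluorophenyl Arm

This account rests on a few compounds, and the source may have more. Where it says the series, first, only, none or still open, it means among the compounds named here.

Three compounds sharing one core, and differing only in the ring attached to the saturated chain carbon, have been tested in a functional assay on cells for agonist activity at G-protein coupled receptor 52 (Homo sapiens), read by AlphaScreen and cAMP accumulation, with a stated time of 30 min; a higher number here means that more compound is needed for the effect, a lower number that less compound is needed. Compound 1 `Cc1cc(-c2sc(Cc3cccc(F)c3)nc2C)ccc1C(N)=O` gives 260 nM in this assay, the second highest of the three numbers. Compound 2 `Cc1cc(-c2sc(Cc3cccc(Cl)c3)nc2C)ccc1C(N)=O` gives 130 nM, and a 2.0-fold lower number from compound 1 to compound 2 (0.30 log units; within the scatter), so these two cannot be told apart. Compound 3 `Cc1cc(-c2sc(Cc3ccccc3Cl)nc2C)ccc1C(N)=O` gives 3900 nM; here a 15-fold higher number from compound 1 to compound 3 (1.18 log units; beyond the scatter), and a 30-fold higher number from compound 2 to compound 3 (1.48 log units; beyond the scatter).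

Compound 4 `Cc1cc(-c2sc(Cc3cc(F)cc(C(F)(F)F)c3)nc2C)ccc1C(N)=O` is derived from compound 1 by trifluoromethyl in place of hydrogen on an aromatic carbon. The fluoro group of compound 1 remains, and a second substituent joins it on the same ring.

Two kinds of measured step bear on this. The step from compound 1 to compound 2 shows that exchanging one halogen for another at its existing place changes the number little. The steps leading to compound 3 show that relocating a halogen to a different ring carbon changes the number greatly. For the measured compounds named here, no measured step adds a second group while keeping the fluoro group where it is, so the expectation rests on the nearer precedent: in this assay compound 4 is expected to show a 1.3-fold higher number from compound 1 to compound 4 (0.13 log units; within the scatter), a modest change at most. The estimate for compound 4 is 350 nM, with a range from 100 nM to 1200 nM.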

Compound 4, half-maximal effective concentration: 11 nM
Beside the measured number, compound 4's estimate is 32-fold (1.50 log units) above it; the whole stated range lies above it.
By their numbers in this assay, from the lowest: compound 4; then compounds 2 and 1 (each within the scatter of the next); then compound 3.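

In this assay, adding trifluoromethyl to the aromatic carbon meta to the fluoro group gives a 24-fold lower number from compound 1 to compound 4 (1.37 log units; beyond the scatter). For the compounds shown here, this is the first large step in the set towards a lower number, since the earlier large steps, a 15-fold higher number from compound 1 to compound 3 (1.18 log units; beyond the scatter) and a 30-fold higher number from compound 2 to compound 3 (1.48 log units; beyond the scatter), both ran towards a higher one, and exchanging one halogen for another, a 2.0-fold lower number from compound 1 to compound 2 (0.30 log units; within the scatter), gave no hint of such a gain. The ring of compound 1 therefore has a carbon, bearing only hydrogen there, where a second substituent of 4 heavy atoms goes with far less compound being needed for the effect, although nothing available explains why.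

On these data alone, what remains open is whether this gain belongs to trifluoromethyl itself or would also come with another group on the same carbon, such as a methyl, a methoxy, a nitrile or an amine. As far as these compounds go, it is also open how much the fluoro group contributes, which a version of compound 4 carrying hydrogen or chloro in its place would help to show.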